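Swapping fluorophenyl for aminophenyl on the carbonyl carbon

This account rests on a few compounds, and the source may have more. Where it says the series, first, only, none or still open, it means among the compounds named here.

Compound 1 `O=C(/C=C/c1ccc2c(c1)B(O)OC2)c1cccnc1`, compound 2 `O=C(/C=C/c1ccc2c(c1)B(O)OC2)c1ccc(O)cc1` and compound 3 `O=C(/C=C/c1ccc2c(c1)B(O)OC2)c1ccccc1F` share one core and differ only in the aromatic ring attached to the carbonyl carbon. In a toxicity assay on WI-38 cells (Homo sapiens) for cytotoxicity, read by MTT assay, with a stated time of 48 h (on this read-out lower numbers stand for stronger inhibition and higher numbers for weaker inhibition), compound 1 gives 76200 nM. In this assay compound 3 gives 23600 nM, the lowest of the two numbers recorded. Compound 2 gives > 100000 nM, which is a limit of this assay rather than a number (the limit of > 100000 nM in this assay, at which 1 of the 3 values shown sits). The two measured steps that lead to compound 3 point the same way: a 3.2-fold lower number from compound 1 to compound 3 (0.51 log units; beyond the scatter), and an at least 4.2-fold lower number from compound 2 to compound 3 (0.62 log units; beyond the scatter). In both, an aromatic ring carrying a nitrogen or a hydroxyl gives way to 2-fluorophenyl, and the number falls.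

Compound 4 `Nc1cccc(C(=O)/C=C/c2ccc3c(c2)B(O)OC3)c1` has not been measured. Relative to compound 3 it differs in one place: 3-aminophenyl in place of 2-fluorophenyl on a carbonyl carbon. Here the direction of the measured steps is reversed: 2-fluorophenyl leaves and a ring bearing an amine enters. A modestly higher number in this assay is therefore expected, roughly undoing the earlier fall. The expected step is a 2.5-fold higher number from compound 3 to compound 4 (0.41 log units; beyond the scatter). Compound 4 is estimated at 60000 nM, within a range from 25000 nM to 150000 nM, with a real chance that only a limit is reported.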

Compound 4, half-maximal inhibitory concentration: 25300 nM
The estimate for compound 4 lay 2.4-fold (0.38 log units) above the measured number, within the range that was stated.
By their numbers in this assay, from the lowest: compounds 3 and 4 (each within the scatter of the next); then compound 1. At a limit, above all of these: compound 2.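

In this assay, the step to 3-aminophenyl is a 1.1-fold higher number from compound 3 to compound 4 (0.03 log units; within the scatter), so on this carbonyl carbon the two rings cannot be told apart, although 3-aminophenyl carries a hydrogen-bond donor and acceptor and 2-fluorophenyl carries neither. Among the compounds shown here, this goes against the reading the earlier compounds allowed, that a ring carrying a nitrogen or a hydroxyl goes with a higher number: a ring bearing an amine gives a 3.0-fold lower number from compound 1 to compound 4 (0.48 log units; beyond the scatter), so a nitrogen alone does not decide the outcome, and compounds 1 and 2 remain the ones that fit that reading. Compound 2 holds a limit rather than a number, which makes its step, an at least 3.9-fold lower number from compound 2 to compound 4 (0.59 log units; beyond the scatter), a floor: the limit of > 100000 nM in this assay, at which 1 of the 4 values shown sits.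

What the compounds shown leave open is whether the amine itself or the place it holds on the ring matters, which 4-aminophenyl or 2-aminophenyl would help to settle, and whether 3-hydroxyphenyl would sit with compound 4 or with compound 2. They also give no cause for any of these steps, and they speak only for this one cell toxicity read-out.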